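Trimming a Methoxy Group from Compound 2

The source may report more compounds than this note shows. Statements on the series, on what has been measured and on what is new or still open speak of the compounds shown alone.

Compound 1 `Nc1cc(N)c2nc(-c3ccccc3)c(Oc3ccc(Cl)c(Cl)c3)nc2c1`: 20400 nM
Compound 2 `COc1ccc(CNc2nc3cc(N)cc(N)c3nc2-c2ccccc2)cc1OC`: 7940 nM
Compound 3 `COc1cc(CNc2nc3cc(N)cc(N)c3nc2-c2ccccc2)cc(OC)c1OC`: 3800 nM

In a functional assay on COLO 205 cells (Homo sapiens) for inhibition, read by sulforhodamine B assay, with a stated time of 48 h (on this read-out lower numbers stand for stronger inhibition of growth and higher numbers for weaker inhibition of growth), compound 2 holds the second highest of the three numbers: compound 3 sits lower, by the step of a 2.1-fold lower number from compound 2 to compound 3 (0.32 log units; beyond the scatter), while compound 1 gives the highest number of all. Compound 4 `COc1ccc(CNc2nc3cc(N)cc(N)c3nc2-c2ccccc2)cc1` differs from compound 2 by hydrogen in place of methoxy on an aromatic carbon. For the measured compounds named here, the only measured step that speaks to this place is a 2.1-fold lower number from compound 2 to compound 3 (0.32 log units; beyond the scatter), where a methoxy was added and the number fell modestly. Taking a methoxy away is expected to move the number the other way by a similar modest amount, a 1.8-fold higher number from compound 2 to compound 4 (0.25 log units; within the scatter). Compound 4 is therefore estimated at 14000 nM, with a range from 6000 nM to 35000 nM.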

Compound 4, concentration for 50% growth inhibition: 15500 nM
Beside the measured number, compound 4's estimate is 1.1-fold (0.04 log units) below it; the measured number falls inside the stated range.
By their numbers in this assay, from the lowest: compound 3; then compounds 2, 4 and 1 (each within the scatter of the next, the first and the last beyond it).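

In this assay, for the compounds shown here, cutting 3,4-dimethoxyphenyl back to 4-methoxyphenyl gives a 2.0-fold higher number from compound 2 to compound 4 (0.29 log units; within the scatter) and is the first case here of losing a methoxy rather than gaining one. This methoxy can therefore go without a shift that stands clear of ordinary repeat variation, though a small real effect cannot be ruled out. Nothing available explains this result. Still open, from the compounds shown here alone, is whether a hydroxyl, an amine or a longer ether such as ethoxy on this aromatic carbon would give a number clearly apart from compound 2.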